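The compounds below may be only part of what the source reports. "The series", "measured", "known", "first", "only" and "open" are said of these compounds alone.

This account concerns four close relatives built on a shared core. Compound 1 `COc1ccc(/C=N/NC(=O)c2cnc3c(C(F)(F)F)cccc3c2N[C@@H](CSc2ccccc2)CC(=O)N(C)C)cc1` has in an ADME assay on Vero cells (Chlorocebus sabaeus) for cytotoxicity, read by MTT assay, with a stated time of 72 h (on this read-out higher numbers stand for weaker inhibition and lower numbers for stronger inhibition), the entry "not determined" (no result reported). Compound 2 `COc1ccc(/C=N/NC(=O)c2cnc3c(C(F)(F)F)cccc3c2N[C@@H](CSc2ccccc2)CC(=O)N(C)C)cc1O` gives in this assay a result that is a limit of the assay, > 62.5 ug/mL. Compound 3 `CN(C)C(=O)C[C@H](CSc1ccccc1)Nc1c(C(=O)N/N=C/c2cc(F)ccc2O)cnc2c(C(F)(F)F)cccc12` likewise shows in this assay only "not determined" (no result reported). Compound 3 thus stands without a single number of its own; among its companions one value is a limit and one entry has no number, as recorded in the limit of > 62.5 ug/mL in this assay, at which 1 of the 3 values shown sits. Compound 4 `CCCCCCCC/C=N/NC(=O)c1cnc2c(C(F)(F)F)cccc2c1N[C@@H](CSc1ccccc1)CC(=O)N(C)C` differs from compound 3 in one place: octyl in place of 5-fluoro-2-hydroxyphenyl on a carbon with a double bond to nitrogen. No measured pair differing in one place is available, so the size and direction of the step in this assay rest on nothing measured; the expectation is a value near the one limit shown, with no change beyond the scatter assumed in either direction. Compound 4 is expected to give 50 ug/mL, within a range from 15 ug/mL to 125 ug/mL.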

Compound 4, half-maximal inhibitory concentration: > 62.5 ug/mL
Compound 4 ended at the assay's limit; the forecaster's own chance of this, stated with the estimate: 55%; middle value at least 1.2-fold (0.09 log units) from the limit.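

Compound 2 and compound 4 both end at a limit of this assay, so no step can be read between them: the limit of > 62.5 ug/mL in this assay, at which 2 of the 4 values shown sit. The compounds shown leave open where the true values of compound 2 and compound 4 lie, and so whether octyl in place of 3-hydroxy-4-methoxyphenyl shifts the result in this assay at all.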